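The source may hold more compounds than are shown below. What is called first, only, known or untested is meant among the compounds shown, and "the series" means these compounds.

Measured in a functional assay on P388 cells (Mus musculus) for cytotoxicity; on this read-out lower numbers stand for stronger inhibition and higher numbers for weaker inhibition:
- compound 1 `Cc1cc(-c2c(F)cc3c(=O)c(Cc4cccc(O)c4)cn(C4CC4)c3c2F)cc(C)n1`: 2200 nM
- compound 2 `Cc1cc(-c2c(F)cc3c(=O)c(C(=O)O)cn(C4CC4)c3c2F)cc(C)n1`: 29000 nM

Compound 2 has the higher of the two numbers, at 29000 nM. Compound 3 `Cc1cc(-c2c(F)cc3c(=O)c(Cc4ccc(O)cc4)cn(C4CC4)c3c2F)cc(C)n1` has not yet been measured. It differs from compound 2 by 4-hydroxybenzyl in place of carboxy on an aromatic carbon. Within the data shown here, compound 1 supplies the only measured step that bears on this: a 13-fold higher number from compound 1 to compound 2 (1.12 log units; beyond the scatter), a large step for the reverse kind of exchange, with 3-hydroxybenzyl. No data yet compare 4-hydroxybenzyl with 3-hydroxybenzyl. A step of similar size toward a lower number is therefore expected in this assay, namely a 12-fold lower number from compound 2 to compound 3 (1.06 log units; beyond the scatter). The estimate for compound 3 is 2500 nM, with an expected range of 800 nM to 8000 nM.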

Compound 3, half-maximal inhibitory concentration: 1500 nM
Compound 3: the middle estimate sits 1.7-fold (0.22 log units) above what was measured, within the range that was stated.
By their numbers in this assay, from the lowest: compounds 3 and 1 (each within the scatter of the next); then compound 2.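

In this assay, 4-hydroxybenzyl in place of carboxy gives a 19-fold lower number from compound 2 to compound 3 (1.29 log units; beyond the scatter) and remains a large step, so the drop in number at this position is not confined to the 3-hydroxybenzyl group. Changing 3-hydroxyphenyl to 4-hydroxyphenyl on the chain carbon gives a 1.5-fold lower number from compound 1 to compound 3 (0.17 log units; within the scatter), so this assay does not separate the two hydroxyl placements. No supporting data explain these steps. Still open, on these data alone, is whether the hydroxyl group matters at all, as an unsubstituted benzyl group would show. As far as these compounds go, a 4-methoxybenzyl or 4-aminobenzyl group at this position also remains open.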